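Amine variation on the shared core, binding read-out

The source may report more compounds than this note shows. Statements on the series, on what has been measured and on what is new or still open speak of the compounds shown alone.

Measured so far:
compound 1 `CCCN(CCC)Cc1ccc(Cl)c(-c2ccccc2OC)c1` — > 10000 nM
compound 2 `CNCc1ccc(Cl)c(-c2ccccc2OC)c1` — > 10000 nM

In an assay on isolated protein for binding affinity to 5-hydroxytryptamine receptor 3A (Homo sapiens) (on this read-out lower numbers stand for stronger inhibition and higher numbers for weaker inhibition), compound 1 gives > 10000 nM, which is a limit of the assay and not a number. Compound 2 gives > 10000 nM in this assay, likewise a limit. Compound 2 therefore stands only at a limit; it has no numeric value of its own. Among the measured compounds shown here, the one measured step, a step that the two limits leave unreadable from compound 1 to compound 2, cannot be read because both values sit at the limit of > 10000 nM in this assay, at which 2 of the 2 values shown sit.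

Compound 3 `CCN(CC)Cc1ccc(Cl)c(-c2ccccc2OC)c1` is to be measured in this assay. The change from compound 2 is diethylamino in place of methylamino on a saturated chain carbon bound to an aromatic carbon. For the measured compounds named here, the only measured step bears on the same place, the saturated chain carbon bound to an aromatic carbon, and it is unreadable in size; diethylamino is, in heavy-atom count, between the methylamino of compound 2 and the dipropylamino of compound 1, both of which sit at the limit. No step beyond the scatter can therefore be expected to show, and the most probable outcome for compound 3 is again a limit. Compound 3 is expected at 20000 nM, with a range from 6000 nM to 100000 nM. The expected step that the limit leaves unreadable from compound 2 to compound 3 is thus essentially none readable.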

Compound 3, inhibition constant: > 10000 nM
Compound 3 was reported as a limit (the forecaster's own chance of this, stated with the estimate: 85%); the middle value is on the limit's open side.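

In this assay compound 3 gives > 10000 nM, which is a limit of the assay and not a number. No new step can be read from compound 3 to compound 1 or compound 2, because all the values sit at one limit: the limit of > 10000 nM in this assay, at which 3 of the 3 values shown sit.

The compounds shown leave open how methylamino, diethylamino and dipropylamino differ in this read-out, and whether any amine on the shared core gives a numeric value.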